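Positional fluorine swap on the amide aryl of a mGlu5 PAM series

This account rests on a few compounds, and the source may have more. Where it says the series, first, only, none or still open, it means among the compounds named here.

Compounds measured so far in an assay on HEK293 cells for positive allosteric modulation of metabotropic glutamate receptor 5 (Homo sapiens), read by FLIPR; a lower number here means that less compound is needed, a higher number that more compound is needed for the effect:
compound 1 `O=C(c1cccc(F)c1)N1CC(c2nc(-c3cccc(Cl)c3)no2)C1` gives > 10000 nM, which is a limit of the assay.
Compound 2 `Cc1cccc(-c2noc(C3CN(C(=O)c4ccccc4F)C3)n2)c1` gives > 10000 nM, a limit.
Compound 3 `O=C(c1ccccc1F)N1CC(c2nc(-c3cccc(Cl)c3)no2)C1` gives > 10000 nM, also a limit.

For the measured compounds named here, compound 2 thus stands at the limit only, with no number of its own; every value so far sits there (the limit of > 10000 nM in this assay, at which 3 of the 3 values shown sit). Compound 4 `Cc1cccc(-c2noc(C3CN(C(=O)c4cccc(F)c4)C3)n2)c1` differs from compound 2 by 3-fluorophenyl in place of 2-fluorophenyl on a carbonyl carbon. Going by the values given here, the same swap, in the other direction, is the only measured step that bears on it: a step that the two limits leave unreadable from compound 1 to compound 3, which the two limits leave unreadable; a step that the two limits leave unreadable from compound 2 to compound 3 is unreadable for the same reason. No direction can be read. Compound 4 is therefore expected to remain at or near the limit, with the step that the limit leaves unreadable from compound 2 to compound 4 estimated as none beyond the scatter. The estimate for compound 4 is 15000 nM, within 5000 nM to 50000 nM.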

Compound 4, half-maximal effective concentration: > 10000 nM
Compound 4 was reported as a limit (the forecaster's own chance of this, stated with the estimate: 85%); the middle value does not contradict the limit.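

Neither step to compound 4, from compound 2 or from compound 1, can be read, and all four compounds share one limit: the limit of > 10000 nM in this assay, at which 4 of the 4 values shown sit.

The compounds shown leave open whether either swap, fluorine position or chloro for methyl, alters the half-maximal effective concentration on a measurable scale.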